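The source may hold more compounds than are shown below. What is called first, only, known or untested is meant among the compounds shown, and "the series" means these compounds.

Compound 1 `COc1cc(-c2nnc3n2NC(c2ccco2)C(C(=O)c2ccccc2F)S3)cc(OC)c1OC`: in a functional assay on A549 cells (Homo sapiens) for cytotoxicity, read by MTT assay, with a stated time of 48 h (on this read-out lower numbers stand for stronger inhibition and higher numbers for weaker inhibition), compound 1 gives 78700 nM.
Compound 2 `COc1cc(-c2nnc3n2NC(c2ccco2)C(C(=O)c2ccc(Br)cc2)S3)cc(OC)c1OC`: in this assay compound 2 gives 42100 nM.
Compound 3 `COc1cc(-c2nnc3n2NC(c2ccco2)C(C(=O)c2ccc(Cl)cc2)S3)cc(OC)c1OC`: in this assay compound 3 gives 51400 nM.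

All three share one core and differ only in the aryl group on the carbonyl carbon. Compound 1 has the highest of the three numbers, but every gap to it lies within the scatter: a 1.9-fold lower number from compound 1 to compound 2 (0.27 log units; within the scatter) and a 1.5-fold lower number from compound 1 to compound 3 (0.19 log units; within the scatter), and between the two halogenated analogues a 1.2-fold higher number from compound 2 to compound 3 (0.09 log units; within the scatter). Compound 4 `COc1cc(-c2nnc3n2NC(c2ccco2)C(C(=O)c2ccc(F)cc2)S3)cc(OC)c1OC` is not yet measured; its change from compound 1 is 4-fluorophenyl in place of 2-fluorophenyl on a carbonyl carbon. Both measured swaps of the aryl group at this carbonyl carbon stayed within the scatter, so no step beyond the scatter is expected here either, a 1.3-fold lower number from compound 1 to compound 4 (0.12 log units; within the scatter). Compound 4 is therefore estimated at 60000 nM, with a range from 25000 nM to 150000 nM.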

Compound 4, half-maximal inhibitory concentration: 53700 nM
For compound 4 the middle estimate is 1.1-fold (0.05 log units) above the measured one; measured number inside the range.
By their numbers in this assay, from the lowest: compounds 2, 3, 4 and 1 (each within the scatter of the next).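

Moving the fluoro group, 4-fluorophenyl in place of 2-fluorophenyl on the carbonyl carbon, gives no step beyond the scatter (a 1.5-fold lower number from compound 1 to compound 4 (0.17 log units; within the scatter)). The 4-fluorophenyl, 4-chlorophenyl and 4-bromophenyl compounds also cannot be told apart (a 1.0-fold higher number from compound 3 to compound 4 (0.02 log units; within the scatter); a 1.3-fold higher number from compound 2 to compound 4 (0.11 log units; within the scatter)). Nothing available gives a reason for these small steps.

Every aryl group shown carries a single halogen, so what an amine or a carboxylic acid on that phenyl ring would do remains open. On these data alone, whether any change at this carbonyl carbon can move the number beyond the scatter is also open.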